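Sulfonyl aryl change from compound 2 to compound 3

The source may report more compounds than this note shows. Statements on the series, on what has been measured and on what is new or still open speak of the compounds shown alone.

In an ADME assay on HEK293 cells (Homo sapiens) for cytotoxicity, read by resazurin assay, with a stated time of 48 h (a higher number here means that more compound is tolerated, a lower number that less compound is tolerated), compound 1 (`O=S(=O)(Nc1ccc(-c2nc3ccccc3o2)cc1)c1cccc(Cl)c1`) gives > 100000 nM, which is a limit. Compound 2 (`Cc1ccccc1S(=O)(=O)Nc1ccc(-c2nc3ccccc3o2)cc1`) gives > 100000 nM, also a limit. The pair stands as the limit of > 100000 nM in this assay, at which 2 of the 2 values shown sit. For the measured compounds named here, the only measured step, a step that the two limits leave unreadable from compound 1 to compound 2, also changes the group on the sulfonyl sulfur. Compound 3 (`COc1ccc(Cl)cc1S(=O)(=O)Nc1ccc(-c2nc3ccccc3o2)cc1`) carries 5-chloro-2-methoxyphenyl in place of 2-methylphenyl on a sulfonyl sulfur. With no readable step to go on, none beyond the scatter is expected in this assay. The expected step is a number no higher from compound 2 to compound 3 (the limit leaves the size open). For compound 3 the estimate is 100000 nM, with an expected range of 40000 nM to 200000 nM.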

Compound 3, half-maximal cytotoxic concentration: 75000 nM
For compound 3 the middle estimate is 1.3-fold (0.12 log units) above the measured one; low and high end bracket the measured number.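

In this assay, for the compounds shown here, compound 3 is the first of the series to give a number rather than a limit, with 5-chloro-2-methoxyphenyl on the sulfonyl sulfur. The reading is an at least 1.3-fold lower number from compound 2 to compound 3 (0.12 log units; that floor lies within the scatter) and an at least 1.3-fold lower number from compound 1 to compound 3 (0.12 log units; that floor lies within the scatter) so neither change is shown to go beyond the scatter. The other two compounds stay at a limit: the limit of > 100000 nM in this assay, at which 2 of the 3 values shown sit.

The compounds shown leave open whether an amine or a carboxylic acid in place of methoxy on this aromatic ring would give a step beyond the scatter.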